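The compounds below may be only part of what the source reports. "The series", "measured", "known", "first", "only" and "open" are said of these compounds alone.

Compound 1 `O=S(=O)(c1ccc(F)cc1)N(Cc1ccccc1)Cc1cccc(F)c1F` and compound 2 `Cc1ccc(S(=O)(=O)N(Cc2cn(Cc3ccccc3Cl)nn2)Cc2cn(S(=O)(=O)c3ccc(C)cc3)c3ccccc23)cc1` have both been tested in a functional assay on 3T3-L1 cells (Mus musculus) for inhibition, with a stated time of 20 min, tested at 20 uM; a lower number here means less inhibition, a higher number more inhibition at the concentration tested (going by the name of the read-out). In this assay compound 1 gives -81.9%, the lowest of the two numbers shown, while compound 2 gives -4.8%, a gap that lies beyond the usual scatter. Compound 3 `Cc1ccc(S(=O)(=O)N(Cc2ccccc2)Cc2cccc(F)c2F)cc1` has not yet been measured in this assay. It differs from compound 1 by methyl in place of fluoro on an aromatic carbon. Among the measured compounds shown here, no measured pair shows this change, so only a cautious guess is possible: a step of a number 16.9 percentage points higher from compound 1 to compound 3 (beyond the scatter) is expected, modest and upward. For compound 3 the expected value in this assay is -65%, within a range from -95% to -25%.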

Compound 3, a percentage reported as inhibition, at one concentration (the size of the read-out at that concentration, not a potency): -35.7%
Estimate against measurement, compound 3: 29.3 percentage points below; measured number inside the range.
By their numbers in this assay, from the lowest: compound 1; then compound 3; then compound 2.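

Swapping 4-fluorophenyl for 4-methylphenyl is the first change in a single place seen in this assay, and it gives a number 46.2 percentage points higher from compound 1 to compound 3 (beyond the scatter) with the rest of compound 1 kept. So a single heavy atom exchanged at this aromatic carbon is enough to move the read-out well past the usual scatter. Nothing available here accounts for the step.

As far as these compounds go, how a methoxy group or an amine at this same position would read remains open. Also open, from the compounds shown here alone, is whether the same swap would give a similar step on a different core.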